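Dichloro core to monochloro: a predicted loss of potency

This account rests on a few compounds, and the source may have more. Where it says the series, first, only, none or still open, it means among the compounds named here.

Measured compounds and their values:
compound 1, `ClCc1ccc(Cn2cnc3nc(Cl)nc(Cl)c32)cc1`, gives 1770 nM
compound 2, `ClCc1cccc(Cn2cnc3c(Cl)nc(Cl)nc32)c1`, gives 1690 nM
compound 3, `ClCc1ccccc1Cn1cnc2nc(Cl)nc(Cl)c21`, gives 330 nM

These three compounds were tested in a functional assay on U-251 cells (Homo sapiens) for cytotoxicity, read by sulforhodamine B assay, with a stated time of 48 h; on this read-out lower numbers stand for stronger inhibition of growth and higher numbers for weaker inhibition of growth. Compound 1 has the highest number of the three. Compound 2 sits within the scatter of compound 1, so no order can be read between them. Compound 3 lies well beyond the scatter, with a clearly lower number than compound 1.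

The unmeasured compound 4, `ClCc1ccc(Cn2cnc3ncnc(Cl)c32)cc1`, differs from compound 1 in one place: hydrogen in place of chloro on an aromatic carbon. In words, a hydrogen replaces a chloro group on an aromatic carbon of the shared core, on the carbon between two ring nitrogen atoms, meta to the remaining chloro group.

Within the data shown here, no measured pair in this set shows this exact change, so the expected size of the step rests only on the structural difference itself. Removing one of the two chloro groups from the core of compound 1 is expected to weaken inhibition of growth, giving a moderate step upward in this assay, as a 2.0-fold higher number from compound 1 to compound 4 (0.30 log units; within the scatter) expresses. On that basis compound 4 is estimated at 3500 nM, with a range from 1200 nM to 10000 nM.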

Compound 4, concentration for 50% growth inhibition: 1090 nM
The estimate for compound 4 lay 3.2-fold (0.51 log units) above the measured number, and the stated range ends above it.
By their numbers in this assay, from the lowest: compound 3; then compounds 4, 2 and 1 (each within the scatter of the next).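

In this assay, hydrogen in place of chloro on the carbon between two ring nitrogen atoms gives a 1.6-fold lower number from compound 1 to compound 4 (0.21 log units; within the scatter), so this exchange cannot be said to alter growth inhibition in either direction. Among these compounds, all the earlier compounds carried two chloro groups on the shared core, so they could not show whether this chloro group was needed; compound 4, with only one, shows that the value of compound 1 is retained within the scatter without it. Nothing available here bears on why this exchange leaves the number within the scatter.

From the compounds shown here alone, it remains open whether a larger group on the same carbon, such as an amine or a methoxy group, would also leave the number within the scatter, and whether the remaining chloro group can be replaced by hydrogen in the same way. The compounds shown also leave open whether the same hydrogen for chloro exchange on compound 3, which differs from compound 1 in where the chloromethyl group sits, would give a step of similar size.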